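The source may report more compounds than this note shows. Statements on the series, on what has been measured and on what is new or still open speak of the compounds shown alone.

In an ADME assay on microsomes from liver (Homo sapiens) for metabolic stability, with a stated time of 15 min (a higher number here means that more of the compound is left, a lower number that less of the compound is left), compound 2 `CC(=O)N1CCC(C(=O)N2CCC(N3CCN(C(=O)c4cc(-c5ccccc5)nc(-c5ccc6c(ccn6C)c5)c4)CC3)CC2)CC1` stands highest of the two measured compounds at 85%, and compound 1 `CC(=O)N1CCC(C(=O)N2CCC(N3CCN(C(=O)c4cc(-c5ccccc5)nc(-c5ccc6[nH]ccc6c5)c4)CC3)CC2)CC1` gives 64%. The next structure is compound 3 `CC(=O)N1CCC(C(=O)N2CCC(N3CCN(C(=O)c4cc(-c5ccccc5)nc(-c5ccc6[nH]cc(C)c6c5)c4)CC3)CC2)CC1`, which differs from compound 2 as follows: a group of 10 heavy atoms (9 carbon, 1 nitrogen; one five-membered aromatic ring with 1 hetero atom, one six-membered aromatic ring of carbon only) in place of a group of 10 heavy atoms (9 carbon, 1 nitrogen; one five-membered aromatic ring with 1 hetero atom, one six-membered aromatic ring of carbon only), on an aromatic carbon. The two have the same atoms, joined differently. Compound 3 has hydrogen on the aromatic nitrogen, as compound 1 does. Within the data shown here, only one measured step bears on this change: a number 21 percentage points higher from compound 1 to compound 2 (beyond the scatter), with methyl in place of hydrogen on an aromatic nitrogen. Among the measured compounds shown here, no measured step shows what a methyl elsewhere on that group does, so the expectation rests on compound 1 at 64%. A drop of similar size in this assay is expected, with wide uncertainty. The estimated step is a number 23 percentage points lower from compound 2 to compound 3 (beyond the scatter). For compound 3 the expected value is 62%, within an estimated range of 42% to 80%.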

Compound 3, percent of the compound remaining: 72%
The estimate for compound 3 lay 10 percentage points below the measured number; measured number inside the range.
By their numbers in this assay, from the lowest: compounds 1 and 3 (each within the scatter of the next); then compound 2.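

In this assay, methyl in place of hydrogen on an aromatic carbon gives a number 8 percentage points higher from compound 1 to compound 3 (within the scatter), so this methyl shows no readable change, while compound 3 keeps the hydrogen on the aromatic nitrogen. Relocating the methyl from the aromatic nitrogen of the 1-methyl-1H-indol-5-yl group to that aromatic carbon gives a number 13 percentage points lower from compound 2 to compound 3 (beyond the scatter), so among these three compounds the higher number goes with methyl on the aromatic nitrogen, as in a number 21 percentage points higher from compound 1 to compound 2 (beyond the scatter) and not with the added methyl as such. Nothing available explains this difference.
Open, on these data alone, is whether a longer chain such as ethyl on the aromatic nitrogen would hold the number of compound 2 at 85% in this assay. Also open, as far as these compounds go, is how fluorine or a nitrile on that aromatic carbon would compare with the methyl of compound 3.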